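Anilino substituent change: tert-butyl to methoxy

The source may hold more compounds than are shown below. What is called first, only, known or untested is meant among the compounds shown, and "the series" means these compounds.

Within the data shown here, compound 2 `CC(C)(C)c1cccc(NC2=NS(=O)(=O)c3cc([N+](=O)[O-])ccc32)c1` gives 60 nM in an assay on isolated protein for inhibition of Polyunsaturated fatty acid 5-lipoxygenase (Homo sapiens), read by fluorescence and spectrophotometry, with a stated time of 10 min (on this read-out higher numbers stand for weaker inhibition and lower numbers for stronger inhibition), the lowest of the two numbers so far; its nearest neighbour is compound 1 `CC(C)c1cccc(NC2=NS(=O)(=O)c3cc([N+](=O)[O-])ccc32)c1`, which gives 250 nM in this assay, the only measured step being a 4.2-fold lower number from compound 1 to compound 2 (0.62 log units; beyond the scatter). Compound 3 `COc1cccc(NC2=NS(=O)(=O)c3cc([N+](=O)[O-])ccc32)c1` carries methoxy in place of tert-butyl on an aromatic carbon. Among the measured compounds shown here, no measured step covers methoxy; the one step that bears on the change is the gain from compound 1 to compound 2 on enlarging the saturated group, and removing the tert-butyl altogether is expected to give that gain back, likely with something more. For compound 3 the expected step is a 6.7-fold higher number from compound 2 to compound 3 (0.82 log units; beyond the scatter), an estimate of 400 nM with a range from 120 nM to 1300 nM.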

Compound 3, half-maximal inhibitory concentration: 240 nM
Compound 3: the middle estimate sits 1.7-fold (0.22 log units) above what was measured; the range from low to high includes it.
By their numbers in this assay, from the lowest: compound 2; then compounds 3 and 1 (each within the scatter of the next).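

In this assay, methoxy in place of tert-butyl on an aromatic carbon gives a 4.0-fold higher number from compound 2 to compound 3 (0.60 log units; beyond the scatter). This is about the same size as a 4.2-fold lower number from compound 1 to compound 2 (0.62 log units; beyond the scatter), in the opposite direction. Methoxy in place of isopropyl gives a 1.0-fold lower number from compound 1 to compound 3 (0.02 log units; within the scatter), so an oxygen-linked group and a saturated group cannot be told apart here, and among these three groups only tert-butyl stands apart. Nothing available explains these steps.

The compounds shown leave open how an amine or a carboxylic acid on this aromatic carbon would read. On these data alone, whether a longer chain there would give a lower number than compound 2 also stays open.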